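A few compounds are considered here, and "the series" means these few. Any claim that something is new, unique, unknown or untested is made for them only; others in the source may bear on it.

Measured compounds and their numbers:
Compound 1 `Cc1oc(-c2c(Cl)cccc2Br)nc1CN1CCC(C(=O)NCCCN2C[C@H](C)C[C@H](C)C2)CC1`: 12200 nM
Compound 2 `Cc1cccc(F)c1-c1nc(CN2CCC(C(=O)NCCCN3C[C@H](C)C[C@H](C)C3)CC2)c(C)o1`: 13000 nM

Both numbers come from an ADME assay on Huh7.5.1 cells (Homo sapiens) for cytotoxicity, read by ATP content, with a stated time of 48 h; on this read-out lower numbers stand for higher toxicity in this test and higher numbers for lower toxicity in this test. Among these two numbers compound 2 gives the highest, and its nearest neighbour is compound 1, a gap that lies within the scatter. Going by the values given here, the one measured step, a 1.1-fold higher number from compound 1 to compound 2 (0.03 log units; within the scatter), exchanges one aryl group for another at the same carbon of the shared core. Compound 3 `Cc1ccc(-c2nc(CN3CCC(C(=O)NCCCN4C[C@H](C)C[C@H](C)C4)CC3)c(C)o2)cc1C` differs from compound 2 at that very place: 3,4-dimethylphenyl in place of 2-fluoro-6-methylphenyl on an aromatic carbon. Among the compounds with values here, this single earlier step is the only comparison that bears on the new change, and because a 1.1-fold higher number from compound 1 to compound 2 (0.03 log units; within the scatter) stayed within the scatter, no step beyond the scatter is expected here either, in neither direction. Compound 3 is therefore estimated at 13000 nM, with a range from 6500 nM to 26000 nM. The expected step of no change at the digits printed from compound 2 to compound 3 (within the scatter) is essentially nil.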

Compound 3, half-maximal cytotoxic concentration: 6910 nM
Estimate against measurement, compound 3: 1.9-fold (0.27 log units) above; the range from low to high includes it.
By their numbers in this assay, from the lowest: compounds 3, 1 and 2 (each within the scatter of the next).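

In this assay, bringing in 3,4-dimethylphenyl gives a 1.9-fold lower number from compound 2 to compound 3 (0.27 log units; within the scatter), and the same group gives a 1.8-fold lower number from compound 1 to compound 3 (0.25 log units; within the scatter). The earlier step exchanged one halogen-bearing aryl group for another, whereas these steps show that an aryl group with only carbon substituents also stays within the scatter at this carbon, so none of the three aryl groups shown stands apart from the others in this test. Nothing available here explains these small steps.

On these data alone, it remains open whether a group of another kind on this carbon, such as an amine, a carboxylic acid or a pyridine ring, would move the number beyond the scatter. As far as these compounds go, it is also open whether a longer chain elsewhere on the shared core would do so.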